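This account rests on a few compounds, and the source may have more. Where it says the series, first, only, none or still open, it means among the compounds named here.

Working notes on the series. Compound 1 `O=c1ccn(CCCO)c(=O)[nH]1` carries a shared core with a hydroxypropyl chain on the aromatic nitrogen. In an assay on isolated protein for inhibition of Deoxyuridine 5'-triphosphate nucleotidohydrolase, mitochondrial (Homo sapiens) (on this read-out lower numbers stand for stronger inhibition and higher numbers for weaker inhibition), compound 1 gives > 1000000 nM, which is a limit of the assay and not a number. Compound 2 `O=c1ccn(CCCCO[Si](c2ccccc2)(c2ccccc2)c2ccccc2)c(=O)[nH]1` extends the chain and masks the hydroxy as a silyl ether. In this assay compound 2 gives > 1000000 nM, again a limit rather than a number. Going by the values given here, compound 1 therefore stands only at a limit, and the one other value shown is a limit as well; no step between measured compounds can be read.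

Compound 3 `O=c1ccn(CCCCCO)c(=O)[nH]1` differs from compound 1 by 2-hydroxyethyl in place of hydroxy on a saturated chain carbon, three bonds along the chain from an aromatic nitrogen. No step beyond the scatter is expected in either direction, since the limit of > 1000000 nM in this assay, at which 2 of the 2 values shown sit, gives no anchor for movement. Compound 3 is expected to give 2000000 nM, within 500000 nM to 10000000 nM. The estimated step from compound 1 to compound 3 is a step that the limit leaves unreadable from compound 1 to compound 3.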

Compound 3, inhibition constant: > 1000000 nM
Compound 3 ended at the assay's limit; the forecaster's own chance of this, stated with the estimate: 85%; the middle value does not contradict the limit.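

Compound 3, like compound 1, stands at a limit and not at a number, so no step can be read between compound 1 and compound 3: the limit of > 1000000 nM in this assay, at which 3 of the 3 values shown sit. The compounds shown leave open whether any chain on the shared core gives a measurable inhibition constant in this assay.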